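A few compounds are considered here, and "the series" means these few. Any claim that something is new, unique, unknown or untested is made for them only; others in the source may bear on it.

In a functional assay on SGC-7901 cells (Homo sapiens) for inhibition, read by MTT assay, with a stated time of 72 h (a higher number here means a weaker inhibitor, a lower number a stronger inhibitor), compound 2 `Cc1ccc(N2CCCC2)c(C(=O)Nc2ccc(CNC(=O)OCc3cccnc3)cc2)c1` gives 65300 nM, the lowest of the two numbers recorded, while compound 1 `Cc1ccc(C(=O)Nc2ccc(CNC(=O)OCc3cccnc3)cc2)c(N2CCCC2)c1` gives 75200 nM, a gap within the usual scatter, so neither is called the stronger. For compound 3 `O=C(NCc1ccc(NC(=O)c2cccc(F)c2N2CCCC2)cc1)OCc1cccnc1` the assay returns only a limit, > 100000 nM, not a number. Compound 4 `O=C(NCc1ccc(NC(=O)c2cc(-c3ccccc3)ccc2N2CCCC2)cc1)OCc1cccnc1` has not yet been tested in this assay; it differs from compound 2 by phenyl in place of methyl on an aromatic carbon. Among the measured compounds shown here, no measured pair shows what this change does here, so the expectation rests on the weak numbers of the series alone. A small gain in potency is expected, hardly beyond the scatter, with the expected step being a 1.5-fold lower number from compound 2 to compound 4 (0.16 log units; within the scatter). Compound 4 is thus estimated at 45000 nM, between 15000 nM and 120000 nM.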

Compound 4, half-maximal inhibitory concentration: > 100000 nM
Compound 4: a limit, no number; the forecaster's own chance of this, stated with the estimate: 30%; middle value at least 2.2-fold (0.34 log units) from the limit.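

In this assay, phenyl in place of methyl on this aromatic carbon, para to a pyrrolidin-1-yl group, brings no gain in potency and gives an at least 1.5-fold higher number from compound 2 to compound 4 (0.18 log units; that floor lies within the scatter). Compound 4 gives > 100000 nM, which is a limit of the assay and not a number. Only a floor can therefore be put on this change, not its full size: the limit of > 100000 nM in this assay, at which 2 of the 4 values shown sit.

From the compounds shown here alone, whether an ethyl, a methoxy or an amine on this carbon would give a lower number than compound 2 stays open. So does the effect of phenyl here on a core carrying a different group in place of the pyrrolidin-1-yl group.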